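A few compounds are considered here, and "the series" means these few. Any claim that something is new, unique, unknown or untested is made for them only; others in the source may bear on it.

Working notes on the series.

Going by the values given here, compound 1 `Cc1ccc(Nc2cncc(N3CC4CC(C3)N4)c2)cc1` holds the lowest number of the two measured so far in an assay on HEK293 cells for displacement of a labelled ligand from Neuronal acetylcholine receptor; alpha3/beta4 (Homo sapiens); on this read-out higher numbers stand for weaker inhibition and lower numbers for stronger inhibition; in this assay compound 1 gives 1.4 nM. The nearest measured neighbour is compound 2 `Clc1cccc(Nc2ccc(N3CC4CC(C3)N4)cn2)c1`, and in this assay compound 2 gives 4.8 nM, a higher number that lies beyond the scatter. The two differ in more than one place, so this pair does not isolate any single change.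

Compound 3 `c1ccc(Nc2cncc(N3CC4CC(C3)N4)c2)cc1` has not yet been measured. Its difference from compound 1 is hydrogen in place of methyl on an aromatic carbon, or, read one bond further out, phenyl in place of 4-methylphenyl. Among the compounds with values here, no measured pair isolates this change, so nothing beyond the size of the group that leaves can guide the expectation. A small move toward a higher number in this assay is expected, most likely within the scatter or just at its edge; a large shift in either direction would be a surprise. The expected step is a 1.8-fold higher number from compound 1 to compound 3 (0.25 log units; within the scatter). Compound 3 is estimated at 2.5 nM, with a range from 1 nM to 6.5 nM.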

Compound 3, inhibition constant: 0.799 nM
The estimate for compound 3 lay 3.1-fold (0.50 log units) above the measured number; the whole stated range lies above it.
By their numbers in this assay, from the lowest: compounds 3 and 1 (each within the scatter of the next); then compound 2.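

In this assay the pair with hydrogen in place of methyl on an aromatic carbon, para to a large group, shows a 1.8-fold lower number from compound 1 to compound 3 (0.24 log units; within the scatter) and is the only pair shown that isolates a single place. At this position the methyl is thus not required for a number in the range of compound 1: the 4-methylphenyl and phenyl forms cannot be told apart on this read-out, and the one carbon that leaves carries no measurable weight in this pair. No measurement at hand offers an explanation for this result.

On these data alone, it remains open whether the same holds at this place for groups other than methyl, such as methoxy, an amine or a carboxylic acid, since a single pair with the smallest possible group says little about larger or differently built ones. Compound 2 differs from compound 1 and from compound 3 in more than one place, so the contribution of its chlorine or of any other single feature cannot be read from the values shown.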